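Swapping dimethylamino for an ester-bearing side arm

The source may report more compounds than this note shows. Statements on the series, on what has been measured and on what is new or still open speak of the compounds shown alone.

Compound 3 `CN(C)c1c(F)c(N)c2c(=O)cc(-c3ccc(N)c(F)c3)oc2c1F` has been tested in a functional assay on HeLa cells (Homo sapiens) for cytotoxicity, read by neutral red uptake, with a stated time of 3 days; on this read-out higher numbers stand for weaker inhibition and lower numbers for stronger inhibition. Its result of > 100000 nM is a limit of the assay rather than a number. The same holds for compound 1 `CCc1c(F)c(N)c2c(=O)cc(-c3ccc(N)c(F)c3)oc2c1F`, whose result of > 100000 nM is again a limit. Only compound 2 `Nc1ccc(-c2cc(=O)c3c(N)c(F)c(N)c(F)c3o2)cc1F` returns a number in this assay, namely 19000 nM. The step of an at least 5.2-fold lower number from compound 1 to compound 2 (0.72 log units; beyond the scatter) and its counterpart an at least 5.2-fold higher number from compound 2 to compound 3 (0.72 log units; beyond the scatter) set the amino compound apart from the other two, while the step that the two limits leave unreadable from compound 1 to compound 3 cannot be read because both ends sit at the limit of > 100000 nM in this assay, at which 2 of the 3 values shown sit.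

Compound 4 `CN(C)CC(=O)OCc1c(F)c(N)c2c(=O)cc(-c3ccc(N)c(F)c3)oc2c1F` is not yet measured. Its change from compound 3 is ((((dimethylamino)methyl)carbonyl)oxy)methyl in place of dimethylamino on an aromatic carbon. Going by the values given here, no measured step exchanges a dimethylamino for an ester-bearing methyl, so none bears directly on it; the only steps that move the number involve an amino group, which compound 4 does not gain at this position. The step from compound 3 to compound 4 is therefore expected to be a number no higher from compound 3 to compound 4 (the limit leaves the size open), nothing clearly beyond the scatter. Compound 4 is estimated at 100000 nM in this assay, within 30000 nM to 300000 nM, with a fair chance that only a limit is returned again.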

Compound 4, half-maximal inhibitory concentration: 9200 nM
Compound 4: middle estimate off by 11-fold (1.04 log units), on the high side; the measured number lies below the stated range.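

In this assay, the ((((dimethylamino)methyl)carbonyl)oxy)methyl side arm on this aromatic carbon, ortho to two fluoro groups, gives an at least 10-fold lower number from compound 3 to compound 4 (1.03 log units; beyond the scatter). Seen from the ethyl group, putting (((dimethylamino)methyl)carbonyl)oxy in place of its methyl gives an at least 10-fold lower number from compound 1 to compound 4 (1.03 log units; beyond the scatter). Among the earlier compounds only the amino group had returned a number at this position, whereas this side arm, which carries no amino group on the aromatic carbon, goes further still, with a 2.1-fold lower number from compound 2 to compound 4 (0.31 log units; beyond the scatter).

The compounds shown leave open which part of the side arm carries the change, as a hydroxymethyl group or an acetoxymethyl group, without the dimethylamino end, would be needed to separate them. The full size of the two steps starting from a limit also stays open: the limit of > 100000 nM in this assay, at which 2 of the 4 values shown sit.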